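A few compounds are considered here, and "the series" means these few. Any claim that something is new, unique, unknown or untested is made for them only; others in the source may bear on it.

Measured so far:
compound 1 `O=C(Nc1ccc(Cl)c(-c2nnc3c(Cl)cccn23)c1)c1cccnc1` — in a functional assay on AN3-CA cells (Homo sapiens) for antiproliferative activity, read by MTT assay, with a stated time of 72 h (on this read-out higher numbers stand for weaker inhibition and lower numbers for stronger inhibition), compound 1 gives > 100000 nM, a limit of this assay rather than a number.
compound 2 `Cc1cc(Cl)ccc1C(=O)Nc1ccc(Cl)c(-c2nnc3c(Cl)cccn23)c1` — in this assay compound 2 gives > 100000 nM, again a limit and not a number.

Both values sit at the limit of > 100000 nM in this assay, at which 2 of the 2 values shown sit. Going by the values given here, the only step between measured compounds, a step that the two limits leave unreadable from compound 1 to compound 2, therefore has no readable size: the exchange of the group on the carbonyl carbon cannot be scored from two limits. Compound 2 thus stands at the limit of this assay, with no number to place it.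

Compound 3 `O=C(Nc1ccc(Cl)c(-c2nnc3c(Cl)cccn23)c1)c1ccon1` differs from compound 2 in one place: 1,2-oxazol-3-yl in place of 4-chloro-2-methylphenyl on a carbonyl carbon. Among the compounds with values here, the one measured step that touches the same position, from compound 1 to compound 2, is unreadable, so no direction or size of change in this assay can be taken from it. Compound 3 is expected to return a limit as well, estimated at 150000 nM with a range from 30000 nM to 1000000 nM. Within the data shown here, the step this estimate implies, a step that the limit leaves unreadable from compound 2 to compound 3, is an expectation only, with no measured step to support a size.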

Compound 3, half-maximal inhibitory concentration: > 100000 nM
Compound 3: no number, only a limit (the forecaster's own chance of this, stated with the estimate: 85%); the middle value lies beyond the limit too.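

No step among compound 1, compound 2 and compound 3 can be read, as all three values are limits and not numbers: the limit of > 100000 nM in this assay, at which 3 of the 3 values shown sit.

The compounds shown leave open what size of change, if any, the exchange of groups on the carbonyl carbon brings.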